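Hydroxybenzyl for methylpyridinyl on the shared core amine

This account rests on a few compounds, and the source may have more. Where it says the series, first, only, none or still open, it means among the compounds named here.

Measured so far:
compound 1 `N[C@@H]1CCCN(c2cc(Nc3cc(Cl)ccn3)n3nccc3n2)C1`: in an assay on isolated protein for inhibition of Dipeptidyl peptidase 9 (Homo sapiens) (a higher number here means a weaker inhibitor, a lower number a stronger inhibitor), compound 1 gives > 50000 nM, a limit of the assay.
compound 2 `N[C@@H]1CCCN(c2cc(Nc3ccccc3Cl)n3nccc3n2)C1`: compound 2 gives > 100000 nM, again a limit.
compound 3 `Cc1ccnc(Nc2cc(N3CCC[C@@H](N)C3)nc3ccnn23)c1`: compound 3 gives > 100000 nM, also a limit.

Compound 3 thus stands at a limit, as do the other two: two values sit at the limit of > 100000 nM in this assay, at which 2 of the 3 values shown sit, and one at the limit of > 50000 nM in this assay, at which 1 of the 3 values shown sits. The steps a step that the two limits leave unreadable from compound 1 to compound 3 and a step that the two limits leave unreadable from compound 2 to compound 3 are therefore of unknown size, and so is a step that the two limits leave unreadable from compound 1 to compound 2.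

Compound 4 `N[C@@H]1CCCN(c2cc(NCc3ccc(O)cc3)n3nccc3n2)C1` differs from compound 3 as follows: 4-hydroxybenzyl in place of 4-methylpyridin-2-yl on a nitrogen on an aromatic ring. For the measured compounds named here, no measured step reads on this change, and nothing points to a gain. Compound 4 is expected to move by about a number no higher from compound 3 to compound 4 (the limit leaves the size open). Compound 4 is estimated at 100000 nM, with a range of 20000 nM to 300000 nM, most likely again reported as a limit.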

Compound 4, half-maximal inhibitory concentration: > 50000 nM
Compound 4: only a limit was reported; the forecaster's own chance of this, stated with the estimate: 75%; the middle value does not contradict the limit.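

For the compounds shown here, compound 4 stands only at a limit, as do compound 1, compound 2 and compound 3, so no step among them can be read. Still open, as far as these compounds go, is how strongly any of them inhibits in this assay, and whether these replacements change it at all.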